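A few compounds are considered here, and "the series" means these few. Any claim that something is new, unique, unknown or untested is made for them only; others in the source may bear on it.

Going by the values given here, in a functional assay on L1210 cells (Mus musculus) for inhibition (a higher number here means a weaker inhibitor, a lower number a stronger inhibitor), compound 2 `C#CCN(Cc1ccc2nc(C)nc(O)c2c1)c1ccc(C(=O)c2ccccc2)cc1` gives 7700 nM, the only true number measured so far. Compound 1 `C#CCN(Cc1ccc2nc(C)nc(O)c2c1)c1ccc(Cl)cc1` stands at > 4000 nM, which is a limit of the assay and not a number. The next compound, compound 3 `C#CCN(Cc1ccc2nc(C)nc(O)c2c1)c1ccc(S(=O)(=O)C(F)(F)F)cc1`, differs from compound 2 as follows: (trifluoromethyl)sulfonyl in place of benzoyl on an aromatic carbon. It thus carries (trifluoromethyl)sulfonyl in place of benzoyl on an aromatic carbon. Among the compounds with values here, the one measured step at this place is a step that the limit leaves unreadable from compound 1 to compound 2, so it offers no size to carry forward. With no readable step as a guide, no change beyond the scatter is expected in this assay, and the value of compound 2 at 7700 nM remains the sole anchor. The expected change is a 1.1-fold lower number from compound 2 to compound 3 (0.04 log units; within the scatter). Compound 3 is estimated at 7000 nM, with an expected range from 2500 nM to 20000 nM.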

Compound 3, half-maximal inhibitory concentration: 2750 nM
Compound 3: middle estimate off by 2.5-fold (0.41 log units), on the high side; low and high end bracket the measured number.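

In this assay, this position now yields its first readable step, a 2.8-fold lower number from compound 2 to compound 3 (0.45 log units; beyond the scatter), so replacing benzoyl with (trifluoromethyl)sulfonyl moves the number beyond the scatter, even though the entering group carries no ring. The comparison with chloro says less: an at least 1.4-fold lower number from compound 1 to compound 3 (0.16 log units; that floor lies within the scatter) is all that can be read of it. Compound 1 stands at > 4000 nM, which is a limit of the assay and not a number, and the step from it to compound 2 cannot be read: the limit of > 4000 nM in this assay, at which 1 of the 3 values shown sits.

The compounds shown carry only chloro, benzoyl and (trifluoromethyl)sulfonyl here, so how a nitrile, a carboxylic acid or an amine would read at this place remains open. Benzoyl and (trifluoromethyl)sulfonyl also differ in both ring and atoms, and the single step cannot separate the two.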